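Chloro on the anilino ring of compound 2

The compounds below may be only part of what the source reports. "The series", "measured", "known", "first", "only" and "open" are said of these compounds alone.

In a functional assay on HepG2 cells (Homo sapiens) for antiproliferative activity, read by CCK-8 assay, with a stated time of 72 h, tested at 8 uM (on this read-out higher numbers stand for a stronger effect at the one concentration tested and lower numbers for a weaker effect), compound 2 `Nc1ccccc1NC(=O)c1ccc(COCNc2nc(Nc3ccccc3)c3ncn(C4CCCC4)c3n2)cc1` gives 66.9%, the higher of the two numbers recorded so far, while compound 1 `CC(C)n1cnc2c(Nc3ccccc3)nc(NCOCc3ccc(C(=O)Nc4ccccc4N)cc3)nc21` gives 50.2%. For the measured compounds named here, the single measured step, a number 16.7 percentage points higher from compound 1 to compound 2 (beyond the scatter), concerns the group on the aromatic nitrogen of the shared core and not the anilino part. Compound 3 `Nc1ccccc1NC(=O)c1ccc(COCNc2nc(Nc3cccc(Cl)c3)c3ncn(C4CCCC4)c3n2)cc1` differs from compound 2 by chloro in place of hydrogen on an aromatic carbon, so that phenyl becomes 3-chlorophenyl and anilino becomes (3-chlorophenyl)amino. Going by the values given here, no measured pair changes this ring, so nothing among the measured compounds bears directly on the change; the account therefore has no step size to lean on. On that basis the step in this assay is expected to be a number 0.1 percentage points higher from compound 2 to compound 3 (within the scatter), that is, none beyond the scatter. Compound 3 is accordingly estimated at 67%, within a range of 50% to 82%.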

Compound 3, a percentage reported as inhibition, at one concentration (the size of the read-out at that concentration, not a potency): 63.2%
Compound 3: middle estimate off by 3.8 percentage points, on the high side; the range from low to high includes it.
By their numbers in this assay, from the lowest: compound 1; then compounds 3 and 2 (each within the scatter of the next).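

In this assay, for the compounds shown here, the step of a number 3.7 percentage points lower from compound 2 to compound 3 (within the scatter) gives the first reading on the anilino ring, which the earlier pair left untouched. At this place, meta to a large group, a single chloro in place of hydrogen leaves the read-out within the scatter, whereas the earlier step on the aromatic nitrogen, a number 16.7 percentage points higher from compound 1 to compound 2 (beyond the scatter), lay beyond it. No available evidence accounts for this result in terms of the chloro group or the ring that carries it.

The compounds shown leave open whether fluoro, methoxy, trifluoromethyl or an amine at this same place would also stay within the scatter of compound 2. They also leave open whether chloro elsewhere on the ring would do the same, and whether a single concentration hides differences that a full dose-response series would show.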